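Changing the Aryl Group on the Amine Nitrogen

The compounds below may be only part of what the source reports. "The series", "measured", "known", "first", "only" and "open" are said of these compounds alone.

Measured compounds:
compound 1 `Cc1ccc(NC2=CC(=O)c3c(nc4n3[C@H]3OC[C@@H](O)[C@H]3OC4)C2=O)cc1C` — 1050 nM
compound 2 `O=C1C(N2CCCCC2)=CC(=O)c2c1nc1n2[C@H]2OC[C@@H](O)[C@H]2OC1` — > 4000 nM
compound 3 `O=C1C=C(NCc2ccccc2)C(=O)c2c1nc1n2[C@H]2OC[C@@H](O)[C@H]2OC1` — 2670 nM

The three measured compounds share one core and differ only in the group carried on the nitrogen attached to the double-bonded ring carbon. In a functional assay on MGC-803 cells (Homo sapiens) for inhibition, read by sulforhodamine B assay (on this read-out lower numbers stand for stronger inhibition and higher numbers for weaker inhibition), compound 1 gives 1050 nM, the lowest of the two numbers available. Compound 3, with benzylamino in that position, gives 2670 nM, a gap beyond the scatter. Compound 2 reaches only a limit, (the limit of > 4000 nM in this assay, at which 1 of the 3 values shown sits), and so has no number of its own. The step of an at least 3.8-fold higher number from compound 1 to compound 2 (0.58 log units; beyond the scatter) shows that replacing the arylamino group with piperidin-1-yl weakens inhibition by at least a modest amount.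

Compound 4 `CCOc1ccc(NC2=CC(=O)c3c(nc4n3[C@H]3OC[C@@H](O)[C@H]3OC4)C2=O)cc1` keeps the arylamino arrangement and alters only the ring substituents: 4-ethoxyphenyl in place of 3,4-dimethylphenyl on an amine nitrogen. Neither measured step concerns a change within an aryl ring; both remove it altogether. The closest guide is that compound 1, carrying an aromatic ring directly on the nitrogen, holds the lowest number, and compound 4 retains that feature. One therefore expects the step of a 1.2-fold higher number from compound 1 to compound 4 (0.09 log units; within the scatter) to stay within the scatter or to weaken inhibition only slightly. Compound 4 is estimated to give 1300 nM, in a range from 500 nM to 3500 nM.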

Compound 4, half-maximal inhibitory concentration: 2090 nM
For compound 4 the middle estimate is 1.6-fold (0.21 log units) below the measured one; low and high end bracket the measured number.
By their numbers in this assay, from the lowest: compounds 1, 4 and 3 (each within the scatter of the next, the first and the last beyond it). At a limit, above all of these: compound 2.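

Among these compounds, the step of a 2.0-fold higher number from compound 1 to compound 4 (0.30 log units; within the scatter) is the first here that keeps an aromatic ring on the amine nitrogen and changes only what that ring carries, and in this assay it does not separate 4-ethoxyphenyl from 3,4-dimethylphenyl, even though the entering group counts one hydrogen-bond acceptor and the leaving group none. Compound 4 also lies within the scatter of compound 3, so the gap between compound 1 and compound 3 cannot be read as setting every aryl group on this nitrogen apart from benzyl. Nothing given here bears on why the two aryl groups read alike.

The compounds shown leave open whether an aryl ring carrying a carboxylic acid, a dimethylamino group or a chlorine atom would stay level with compound 1 or move clearly away from it. They also leave open how an unsubstituted phenyl group on the amine nitrogen would read in this assay, and whether a longer alkoxy chain than ethoxy would separate from the two aryl groups compared here.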